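The source may report more compounds than this note shows. Statements on the series, on what has been measured and on what is new or still open speak of the compounds shown alone.

Of the compounds shown here, two have been measured in an ADME assay on the whole organism with Oryza sativa as the target, tested at 10 uM; on this read-out higher numbers stand for a weaker effect at the one concentration tested and lower numbers for a stronger effect. Compound 1, `CCc1cccc(NC(=O)N[C@@H](C)c2ccccc2)c1`, gives 86% in this assay. Compound 2, `CC(=O)c1cccc(NC(=O)N[C@H](C)c2ccccc2)c1`, gives 73% in this assay. Going by the values given here, of these two numbers compound 2 holds the lower one, and its nearest neighbour is compound 1, whose number is higher by an amount beyond the usual scatter; no single-change step between these two has been worked out, so only their two values can be compared.

The next compound, compound 3, `CC(=O)c1cccc(NC(=O)N[C@@H](C)c2ccccc2)c1`, has not yet been measured in this assay. Compared with compound 2, it differs as follows: the two compounds have the same atoms and bonds and differ only in configuration as drawn: 1 of 1 stereo elements differ; a stereocentre at a saturated chain carbon is drawn R in compound 2 and S in compound 3. Among the compounds with values here, no pair of compounds with only such a change in configuration has been measured here, so there is nothing to tell how large a change in this assay such a step brings, or in which direction. With no guide of this kind, the step from the measured value of compound 2 is expected to be small and within the scatter, so that a number 3 percentage points higher from compound 2 to compound 3 (within the scatter) is the expected change. Compound 3 is therefore estimated to give 76% in this assay, with a likely range from 55% to 95%.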

Compound 3, a percentage reported as activity, at one concentration (the size of the read-out at that concentration, not a potency): 94%
Compound 3: middle estimate off by 18 percentage points, on the low side, within the range that was stated.
By their numbers in this assay, from the lowest: compound 2; then compounds 1 and 3 (each within the scatter of the next).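

In this assay, turning a single stereocentre at a saturated chain carbon from R to S gives a number 21 percentage points higher from compound 2 to compound 3 (beyond the scatter), so the direction in which this carbon is drawn matters here, with the S form showing the weaker effect at the one concentration tested. With the stereocentre drawn the same way, acetyl in place of ethyl on an aromatic carbon gives a number 8 percentage points higher from compound 1 to compound 3 (within the scatter), so this exchange of groups shows no change that can be told apart from the usual variation between repeats. The gap between the two acetyl compounds can be traced to the stereocentre alone, because nothing else separates them: the fact that compounds 2 and 3 differ only in the configuration as drawn

Going by these compounds alone, only one pair isolates the stereocentre, so it remains open whether the same change would have a similar size or direction with ethyl or any other group on the aromatic carbon. Also open, from the compounds shown here alone, is how an amine, a carboxylic acid or a longer chain at that aromatic carbon would read in this assay, with the stereocentre drawn either way.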